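Three tolerated compounds and a trifluoromethyl swap

This account rests on a few compounds, and the source may have more. Where it says the series, first, only, none or still open, it means among the compounds named here.

Measured so far in an ADME assay on Vero 76 cells (Chlorocebus sabaeus) for cytotoxicity, read by MTT assay, with a stated time of 96 h (a lower number here means that less compound is tolerated, a higher number that more compound is tolerated), are three compounds:
- compound 1 `Cc1ccc(NCc2cn(-c3ccccc3)nc2-c2ccc(Cl)cc2)cc1` gives > 100000 nM as a limit
- compound 2 `Cc1ccc(NCc2cn(-c3ccccc3)nc2-c2ccc(C)cc2)cc1` gives > 100000 nM as a limit
- compound 3 `Cc1ccc(NCc2cn(-c3ccccc3)nc2-c2ccccc2)cc1` gives > 100000 nM as a limit

Compound 1 has no number of its own, since its result of > 100000 nM is a limit. The whole set sits at one mark (the limit of > 100000 nM in this assay, at which 3 of the 3 values shown sit), so compound 1 cannot be ranked against the others.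

Compound 4 `FC(F)(F)c1ccc(NCc2cn(-c3ccccc3)nc2-c2ccc(Cl)cc2)cc1` keeps the core of compound 1 and changes one group (trifluoromethyl in place of methyl on an aromatic carbon), with trifluoromethyl in place of methyl on an aromatic carbon.

Three measured steps are available (a step that the two limits leave unreadable from compound 1 to compound 2; a step that the two limits leave unreadable from compound 1 to compound 3; a step that the two limits leave unreadable from compound 2 to compound 3). They exchange chloro, methyl and hydrogen at another place, and none touches the group that changes in compound 4. They therefore give no size to carry over.

The expectation rests on compound 1 alone, whose > 100000 nM is a limit. The estimated step (an at least 1.2-fold lower number from compound 1 to compound 4 (0.09 log units; that floor lies within the scatter)) is expected to stay within the scatter, and if it shows at all, it is expected to run toward less compound tolerated. Compound 4 is expected at 80000 nM in a range from 30000 nM to 100000 nM by this estimate.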

Compound 4, half-maximal cytotoxic concentration: 18000 nM
Compound 4: middle estimate off by 4.4-fold (0.65 log units), on the high side; measured number below the stated range.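

In this assay, among the compounds shown here, trifluoromethyl in place of methyl on an aromatic carbon, para to a large group, gives an at least 5.5-fold lower number from compound 1 to compound 4 (0.74 log units; beyond the scatter), so this position is the first place where a change is seen to matter. For the compounds shown here, the earlier exchanges of chloro, methyl and hydrogen at another place cannot be read, and compound 4 is the only compound here with a number of its own: the limit of > 100000 nM in this assay, at which 3 of the 4 values shown sit. Compound 1 gives > 100000 nM, which is a limit, so the step is known only as a floor and its full size stays unknown.

The compounds shown leave open whether the lower number is specific to trifluoromethyl or would also appear with another group at this position, such as a methoxy group, an amine or a carboxylic acid. They also leave open whether the same swap would give a step of similar size with methyl or hydrogen in place of chloro at the other position, as in the cores of compound 2 and compound 3.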